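Aryl swap on the amide nitrogen of compound 1

The compounds below may be only part of what the source reports. "The series", "measured", "known", "first", "only" and "open" are said of these compounds alone.

Going by the values given here, in a functional assay on HT-29 cells (Homo sapiens) for cytotoxicity, read by MTT assay, with a stated time of 72 h (on this read-out lower numbers stand for stronger inhibition and higher numbers for weaker inhibition), compound 1 (`O=C(CN1CCN(c2nnc(Cc3ccncc3)c3ccccc23)CC1)Nc1ccc(Br)cc1`) gives 1990 nM, the lower of the two numbers so far. Compound 2 (`O=C(CN1CCN(c2nnc(Cc3ccccc3)c3ccccc23)CC1)Nc1ccc(Br)cc1`) gives 60200 nM.

Compound 3 (`O=C(CN1CCN(c2nnc(Cc3ccncc3)c3ccccc23)CC1)Nc1ccc(F)c(Cl)c1`) carries 3-chloro-4-fluorophenyl in place of 4-bromophenyl on an amide-type nitrogen. Both groups hold one six-membered aromatic ring of carbon only and no net charge.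

Among the compounds with values here, the only measured step is a 30-fold higher number from compound 1 to compound 2 (1.48 log units; beyond the scatter), which is large and beyond the scatter. It belongs to a different place, phenyl in place of pyridin-4-yl on a saturated chain carbon bound to an aromatic carbon, so its size does not carry over to this change. Within the data shown here, no measured pair varies the group on the amide-type nitrogen, which leaves the new step without a direct precedent. No step beyond the scatter is therefore expected in this assay, although the range is kept wide.

The estimated change is a 1.3-fold higher number from compound 1 to compound 3 (0.10 log units; within the scatter). For compound 3 the estimated value is 2500 nM, with an expected range from 700 nM to 9000 nM.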

Compound 3, half-maximal inhibitory concentration: 880 nM
Compound 3: the middle estimate sits 2.8-fold (0.45 log units) above what was measured, within the range that was stated.
By their numbers in this assay, from the lowest: compound 3; then compound 1; then compound 2.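

In this assay the group on the amide-type nitrogen can move the number: 3-chloro-4-fluorophenyl in place of 4-bromophenyl gives a 2.3-fold lower number from compound 1 to compound 3 (0.35 log units; beyond the scatter) as a modest step, the first measured at this position. The change keeps one six-membered aromatic ring of carbon only and no net charge, while one bromine leaves and one fluorine and one chlorine enter, so a halogen swap on that ring is enough to give a step beyond the scatter, though a smaller one than a 30-fold higher number from compound 1 to compound 2 (1.48 log units; beyond the scatter) at the other place. No measured evidence bears on the origin of this step, which therefore stands as an observation only.

The compounds shown leave open whether the same swap would give a similar step with phenyl in place of pyridin-4-yl, as in compound 2. They also leave open how the amide-type nitrogen would read with a phenyl carrying chlorine alone or fluorine alone, with an unsubstituted phenyl, or with a pyridine ring or a cyclohexyl group.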